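Swapping the aryl group on the core: compound 2 to compound 4

The source may hold more compounds than are shown below. What is called first, only, known or untested is meant among the compounds shown, and "the series" means these compounds.

This account follows a series of carboxymethyl-bearing acids tested in an in vitro functional assay on HEK285-7 cells for antagonist activity at prostaglandin D2 receptor 2 (Homo sapiens), read by BRET and beta-arrestin recruitment; a higher number here means a larger maximal response, a lower number a smaller maximal response. Compound 1 `O=C(O)Cc1sc(Cc2ccccc2)nc1-c1ccc(Cl)cc1` gives 50%, and compound 3 `O=C(O)Cc1sc(C(c2ccccc2)c2ccccn2)nc1-c1ccc(Cl)cc1` gives 55%. Within the data shown here, the only single-point step that has been measured is a number 5 percentage points higher from compound 1 to compound 3 (within the scatter). Compound 2 `COc1cc(-c2nc(C(c3ccc(F)cc3)c3ccc(F)cc3)sc2CC(=O)O)ccn1` gives 60%; its number is not separated from that of compound 3 or of compound 1 beyond the scatter, so the three measured compounds cannot be told apart in this assay.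

Compound 4 `N#Cc1ccc(-c2nc(C(c3ccc(F)cc3)c3ccc(F)cc3)sc2CC(=O)O)cc1` differs from compound 2 in one place: 4-cyanophenyl in place of 2-methoxypyridin-4-yl on an aromatic carbon. Among the measured compounds shown here, no measured step touches this position; the step from compound 1 to compound 3 concerns the saturated chain carbon, not the aromatic carbon of the five-membered ring, and it was itself within the scatter. With nothing pointing in either direction, the expectation for compound 4 is a step of about no change at the digits printed from compound 2 to compound 4 (within the scatter), none beyond the scatter. Compound 4 is therefore estimated at 60%, with a range from 45% to 75%.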

Compound 4, largest response reached (reported as efficacy), in percent of the reference or control that the assay uses: 30%
The estimate for compound 4 lay 30 percentage points above the measured number, outside the stated range (below it).
By their numbers in this assay, from the lowest: compound 4; then compounds 1, 3 and 2 (each within the scatter of the next).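

Among these compounds, at the aromatic carbon next to the ring nitrogen, a number 30 percentage points lower from compound 2 to compound 4 (beyond the scatter) in this assay, the first single-place change to move the maximal response beyond the scatter. Among the compounds shown here, the group held at this place therefore matters to the read-out, whereas the only earlier step, at the saturated chain carbon, stayed within the scatter. No measurement given here bears on why 4-cyanophenyl in place of 2-methoxypyridin-4-yl gives this lower number.

The compounds shown do not separate the part played by the nitrile from that of the lost methoxy group and ring nitrogen, and a plain phenyl group at this place would be needed to do so. As far as these compounds go, whether an amine or a carboxylic acid in place of the nitrile would give a similar number also remains open.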